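Ethoxy to trifluoromethyl on the quinoline acid series

The compounds below may be only part of what the source reports. "The series", "measured", "known", "first", "only" and "open" are said of these compounds alone.

The series is read in a functional assay on A-375 cells (Homo sapiens) for antiproliferative activity, read by MTT assay, with a stated time of 24 h, tested at 1.23 ug/mL; on this read-out higher numbers stand for a stronger effect at the one concentration tested and lower numbers for a weaker effect. Compound 3 `CCOc1ccc2nc(C(=O)Nc3c(F)cc(-c4cccc(F)c4)cc3F)c(C)c(C(=O)O)c2c1` gives 26.7%; compound 1 `Cc1c(C(=O)Nc2c(F)cc(-c3cccc(F)c3)cc2F)nc2ccc(C(F)(F)F)cc2c1O` gives 21.3%, and compound 2 `CCc1ccc2nc(C(=O)Nc3c(F)cc(-c4cccc(F)c4)cc3F)c(C)c(C(=O)O)c2c1` gives 17.7%; all three numbers sit within the usual scatter of one another. Within the data shown here, the single measured step, a number 9 percentage points higher from compound 2 to compound 3 (within the scatter), stays within the scatter. Compound 4 `Cc1c(C(=O)Nc2c(F)cc(-c3cccc(F)c3)cc2F)nc2ccc(C(F)(F)F)cc2c1C(=O)O` differs from compound 3 by trifluoromethyl in place of ethoxy on an aromatic carbon. Among the measured compounds shown here, no measured step covers this exchange; compound 1 carries the trifluoromethyl but differs from compound 4 at a second place as well, so only its value can be set beside compound 3. No step beyond the scatter is therefore expected, and the estimated step is a number 4.7 percentage points lower from compound 3 to compound 4 (within the scatter). Compound 4 is expected to give 22%, in the range 10% to 35%.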

Compound 4, a percentage reported as inhibition, at one concentration (the size of the read-out at that concentration, not a potency): 18.3%
For compound 4 the middle estimate is 3.7 percentage points above the measured one; low and high end bracket the measured number.
By their numbers in this assay, from the lowest: compounds 2, 4, 1 and 3 (each within the scatter of the next).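

In this assay, among these compounds, the aromatic carbon now carries ethyl, ethoxy or trifluoromethyl on the same acid core, and no pair separates: a number 8.4 percentage points lower from compound 3 to compound 4 (within the scatter), and a number 0.6 percentage points higher from compound 2 to compound 4 (within the scatter). At the other place, with trifluoromethyl held, carboxy and hydroxy do not separate either: a number 3 percentage points lower from compound 1 to compound 4 (within the scatter). Nothing on hand gives a reason for these steps.

From the compounds shown here alone, whether an amine, a methoxy group or a longer chain at this aromatic carbon would give a step beyond the scatter stays open. Also open, going by these compounds, is how these compounds read at other concentrations.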